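A Methyl Group on the Benzyl Amide

A few compounds are considered here, and "the series" means these few. Any claim that something is new, unique, unknown or untested is made for them only; others in the source may bear on it.

In a functional assay on U-937 cells (Homo sapiens) for antiproliferative activity, read by MTT assay, with a stated time of 24 h (a higher number here means a weaker inhibitor, a lower number a stronger inhibitor), compound 1 `CCCCc1oc2ccccc2c1C(=O)c1ccc(OCC(=O)N2CCCC2)cc1` gives 32500 nM and compound 2 `CCCCc1oc2ccccc2c1C(=O)c1ccc(OCC(=O)NCc2ccccc2)cc1` gives 16300 nM, so compound 2 stands within the scatter of compound 1. Compound 3 `CCCCc1oc2ccccc2c1C(=O)c1ccc(OCC(=O)N[C@H](C)c2ccccc2)cc1` differs from compound 2 by methyl in place of hydrogen on a saturated chain carbon bound to an amide-type nitrogen and an aromatic carbon, turning benzylamino into (1-phenylethyl)amino. For the measured compounds named here, the only measured step, a 2.0-fold lower number from compound 1 to compound 2 (0.30 log units; within the scatter), exchanged the group on the same amide carbonyl and stayed within the scatter, so no change beyond the scatter is expected in this assay. The expected step is a 1.0-fold lower number from compound 2 to compound 3 (0.01 log units; within the scatter). For compound 3 the estimated value is 16000 nM, with an expected range of 7000 nM to 36000 nM.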

Compound 3, half-maximal inhibitory concentration: 19800 nM
Estimate against measurement, compound 3: 1.2-fold (0.09 log units) below; the range from low to high includes it.
By their numbers in this assay, from the lowest: compounds 2, 3 and 1 (each within the scatter of the next).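

In this assay, methyl on the saturated chain carbon bound to an amide-type nitrogen and an aromatic carbon is accepted without a readable shift, the result being a 1.2-fold higher number from compound 2 to compound 3 (0.08 log units; within the scatter). Set against the pyrrolidin-1-yl amide, the (1-phenylethyl)amino group gives a 1.6-fold lower number from compound 1 to compound 3 (0.22 log units; within the scatter), so all three amides lie within the scatter of one another. Nothing at hand accounts for this result. From the compounds shown here alone, whether an ethyl group or a carboxylic acid on that same carbon, or the mirror-image form of the (1-phenylethyl)amino group, would move the number beyond the scatter remains open.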